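Working notes on oral bioavailability: compound 3 to compound 4

This account rests on a few compounds, and the source may have more. Where it says the series, first, only, none or still open, it means among the compounds named here.

Measured compounds in an ADME assay on the whole organism (strain Sprague-Dawley) for pharmacokinetics, with Rattus norvegicus as the target, read by LC-MS, at a dose of 25 mg/kg by the oral route; a higher number here means that a larger share of the oral dose reaches the circulation, a lower number that a smaller share of the oral dose reaches the circulation:
compound 1 `C=CC(=O)N1CC[C@H](N2C(=O)N(Cc3ccccc3)Cc3cnc(Nc4ccc(N5CCN(C)CC5)cc4OC)nc32)C1` gives 24%
compound 2 `C=CC(=O)N1CC[C@H](N2C(=O)N(c3ccccc3)Cc3cnc(Nc4cccc(N5CCN(C)CC5)c4)nc32)C1` gives 20%
compound 3 `C=CC(=O)N1CC[C@H](N2C(=O)N(c3ccccc3)Cc3cnc(Nc4ccc(N5CCN(C)CC5)cc4)nc32)C1` gives 54%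

Compound 3 stands highest of the three numbers in this assay. The nearest, compound 1, sits lower by a gap beyond the scatter; compound 2 sits furthest below, also beyond the scatter. Among the measured compounds shown here, no two measured compounds differ in only one place, so no single-change step can be read from these numbers.

Compound 4 `C=CC(=O)N1CC[C@H](N2C(=O)N(c3ccccc3)Cc3cnc(Nc4ccc(N5CCN(C)CC5)c(C)c4)nc32)C1` differs from compound 3 in one place: methyl in place of hydrogen on an aromatic carbon. For the measured compounds named here, nothing among the measured compounds covers a change of this kind, so the expectation rests on the size of the change alone: one carbon added to a large shared core. No step beyond the scatter is expected in this assay, with at most a slight drift downward. Compound 4 is therefore estimated at 46%, with a range of 22% to 70%. The expected step is a number 8 percentage points lower from compound 3 to compound 4 (within the scatter), within the usual scatter.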

Compound 4, oral bioavailability: 30%
The estimate for compound 4 lay 16 percentage points above the measured number; low and high end bracket the measured number.
By their numbers in this assay, from the lowest: compounds 2, 1 and 4 (each within the scatter of the next); then compound 3.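

In this assay, among the compounds shown here, methyl in place of hydrogen on an aromatic carbon, ortho to a 4-methylpiperazin-1-yl group, gives a number 24 percentage points lower from compound 3 to compound 4 (beyond the scatter) and provides the first single-change step. For the compounds shown here, at this position, the addition of one heavy atom to the large shared core is enough to move oral bioavailability beyond the scatter, which the earlier compounds, all differing in more than one place, could not show. No measurement available here bears on what lies behind this step.

The compounds shown leave open whether this step is particular to methyl or would also appear with a fluorine atom, a hydroxyl or an amine on the same aromatic carbon. They also leave open whether methyl on another carbon of that ring would give a similar step.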